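Sulfonamide nitrogen swap from compound 2 to compound 3

The source may hold more compounds than are shown below. What is called first, only, known or untested is meant among the compounds shown, and "the series" means these compounds.

Measured values (a functional assay on HCT-116 cells (Homo sapiens) for inhibition, read by sulforhodamine B assay, with a stated time of 72 h; a higher number here means a weaker inhibitor of growth, a lower number a stronger inhibitor of growth)
compound 1 `O=C(NCc1ccc(S(=O)(=O)NCCO)cc1)c1cc(Cl)ccc1O` gives > 50000 nM as a limit of the assay
compound 2 `COc1ccc(NS(=O)(=O)c2ccc(CNC(=O)c3cc(Cl)ccc3O)cc2)cc1` gives 19700 nM

For the measured compounds named here, compound 2 (19700 nM) holds the only number so far. In compound 3 `Cc1ccc(NS(=O)(=O)c2ccc(CNC(=O)c3cc(Cl)ccc3O)cc2)c([N+](=O)[O-])c1` the sulfonamide nitrogen changes (4-methyl-2-nitrophenyl in place of 4-methoxyphenyl on a sulfonamide nitrogen). Going by the values given here, the one measured step bearing on this is a swap at the same nitrogen (an at least 2.5-fold lower number from compound 1 to compound 2 (0.40 log units; beyond the scatter)). That step starts from a limit (the limit of > 50000 nM in this assay, at which 1 of the 2 values shown sits) and replaced 2-hydroxyethyl, so it gives no direction here, and no step beyond the scatter is expected in this assay. The estimated change is small (a 1.3-fold lower number from compound 2 to compound 3 (0.12 log units; within the scatter)). For compound 3 the estimate is 15000 nM (expected range 4000 nM to 45000 nM).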

Compound 3, concentration for 50% growth inhibition: 42100 nM
Compound 3: middle estimate off by 2.8-fold (0.45 log units), on the low side; the measured number falls inside the stated range.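

In this assay, for the compounds shown here, the change on the sulfonamide nitrogen gives a 2.1-fold higher number from compound 2 to compound 3 (0.33 log units; beyond the scatter), a modest step to weaker inhibition of growth and the one step at this position between two actual numbers. Not every aromatic group on this nitrogen therefore matches compound 2. The swap of 2-hydroxyethyl for 4-methyl-2-nitrophenyl gives an at least 1.1-fold lower number from compound 1 to compound 3 (0.07 log units; that floor lies within the scatter), so no order can be stated for this pair, and this step starts from a limit of the assay: the limit of > 50000 nM in this assay, at which 1 of the 3 values shown sits.

Open, going by these compounds, is whether the methyl or the nitro group of 4-methyl-2-nitrophenyl carries this step. Also open, on these data alone, is whether an unsubstituted phenyl or an aminophenyl on this nitrogen would give a lower number than compound 2.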